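The source may report more compounds than this note shows. Statements on the series, on what has been measured and on what is new or still open speak of the compounds shown alone.

In a toxicity assay on NIH3T3 cells (Mus musculus) for cytotoxicity, read by resazurin assay (a lower number here means that less compound is needed, a higher number that more compound is needed for the effect), compound 1 (`CN(C)c1ccc(NCc2cncn2Cc2ccc(-c3ccccc3)cc2)cc1-c1ccccc1`) gives > 1000 nM as its reading, which is a limit of the assay and not a number. In this assay compound 2 (`COC(=O)c1ccc(NCc2cncn2Cc2ccccc2C)cc1-c1ccccc1`) gives 10000 nM as a true measured number on a differently substituted relative. Compound 3 (`CNC(=O)c1ccc(NCc2cncn2Cc2ccc(-c3ccccc3)cc2)cc1-c1ccccc1`) has not yet been measured. It departs from compound 1 in one place (methylcarbamoyl in place of dimethylamino on an aromatic carbon): methylcarbamoyl stands in place of dimethylamino on an aromatic carbon, ortho to a phenyl group. Within the data shown here, no measured step between close neighbours is available, so the size of this change in this assay can only be judged loosely. Among the measured compounds shown here, the one true number, compound 2 at 10000 nM on the scale, points to readings that sit high, and no large move towards less compound being needed is expected. The step is estimated as a step that the limit leaves unreadable from compound 1 to compound 3 and is reckoned from a limit alone, so it is a loose expectation. Compound 3 is expected at 5000 nM with an estimated range from 1500 nM to 20000 nM on this measure.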

Compound 3, half-maximal effective concentration: > 1000 nM
Compound 3: only a limit was reported (the forecaster's own chance of this, stated with the estimate: 60%); the middle value is on the limit's open side.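

Among these compounds, compound 1 and compound 3 both stop at a limit of the assay rather than at a number, so no step between them can be read: the limit of > 1000 nM in this assay, at which 2 of the 3 values shown sit. The compounds shown leave open how far methylcarbamoyl in place of dimethylamino moves the reading in this assay and where the true values of these two compounds lie.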